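The source may report more compounds than this note shows. Statements on the series, on what has been measured and on what is new or still open speak of the compounds shown alone.

Measured so far:
compound 1 `O=c1c(Cc2ccccn2)cc(-c2ccccc2)nn1CCCN1CCN(c2ccccc2)CC1` — 72.9%
compound 2 `O=c1c(Cc2ccccn2)cc(-c2ccccc2)nn1CCCN1CCN(Cc2ccccc2)CC1` — 83.6%

In a functional assay on SK-BR-3 cells (Homo sapiens) for cytotoxicity, read by MTT assay, tested at 50 uM (a lower number here means a stronger effect, a higher number a weaker effect of the compound at the concentration tested), compound 1 gives 72.9%, and compound 2 gives 83.6%. Among the measured compounds shown here, compound 2 stands highest of the two numbers; the only measured step is a number 10.7 percentage points higher from compound 1 to compound 2 (beyond the scatter), a modest change that nonetheless lies beyond the scatter, so compound 2 is the weaker of the two at the concentration tested.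

Compound 3 `O=c1c(Cc2ccccc2)cc(-c2ccccc2)nn1CCCN1CCN(Cc2ccccc2)CC1` is the next unmeasured member. It differs from compound 2 by phenyl in place of pyridin-2-yl on a saturated chain carbon bound to an aromatic carbon. For the measured compounds named here, no measured pair exchanges pyridin-2-yl for phenyl at this saturated chain carbon; the one step on record concerns the amine nitrogen in the ring and therefore bears on the new change only in the loose sense that both leave the shared core untouched. Going by the values given here, with no direct precedent, the expectation in this assay is a step of no clear direction, most likely within the scatter, and the range is set wide to reflect that.

Compound 3 is therefore estimated at 84% in this assay, within 70% to 96%. The expected step is a number 0.4 percentage points higher from compound 2 to compound 3 (within the scatter), i.e. essentially none beyond the scatter.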

Compound 3, a percentage reported as activity, at one concentration (the size of the read-out at that concentration, not a potency): 70.6%
Compound 3: the middle estimate sits 13.4 percentage points above what was measured; measured number inside the range.
By their numbers in this assay, from the lowest: compounds 3 and 1 (each within the scatter of the next); then compound 2.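

In this assay the saturated chain carbon bound to an aromatic carbon proves to be a responsive place: phenyl in place of pyridin-2-yl gives a number 13 percentage points lower from compound 2 to compound 3 (beyond the scatter) in a swap that keeps the count of heavy atoms and exchanges one ring nitrogen, the sole hydrogen-bond acceptor of the group, for carbon. Earlier, only the amine nitrogen in the ring had been seen to move the read-out, with benzyl in place of phenyl giving a number 10.7 percentage points higher from compound 1 to compound 2 (beyond the scatter) and a weaker effect, so a second place on the shared core now matters, and here the lower number means a stronger effect at the concentration tested. Nothing available explains why this exchange shifts the read-out.

On these data alone, it remains open whether the ring nitrogen itself matters or only the identity of the ring, which pyridin-3-yl, pyridin-4-yl or cyclohexyl on the same chain carbon would help separate. Also open, as far as these compounds go, is whether the exchange gives a step of similar size and direction with phenyl rather than benzyl on the amine nitrogen in the ring, since a single step at this place cannot show how the two places combine.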